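The compounds below may be only part of what the source reports. "The series", "measured", "known", "first", "only" and "open" are said of these compounds alone.

Measured in an ADME assay on NIH3T3 cells (Mus musculus) for cytotoxicity, read by MTT assay; on this read-out higher numbers stand for weaker inhibition and lower numbers for stronger inhibition:
compound 1 `N#Cc1c(-c2ccccc2O)c(C#N)c(=O)n(/N=C/c2cn(-c3ccccc3)nc2-c2ccccc2)c1N` gives 162 ug/mL
compound 2 `N#Cc1c(-c2cccc(F)c2)c(C#N)c(=O)n(/N=C/c2cn(-c3ccccc3)nc2-c2ccccc2)c1N` gives 154 ug/mL
compound 3 `COc1cc(-c2c(C#N)c(N)n(/N=C/c3cn(-c4ccccc4)nc3-c3ccccc3)c(=O)c2C#N)cc(OC)c1OC` gives 64 ug/mL

Compound 3 has the lowest number of the three: the steps of a 2.5-fold lower number from compound 1 to compound 3 (0.40 log units; beyond the scatter) and a 2.4-fold lower number from compound 2 to compound 3 (0.38 log units; beyond the scatter) both lie beyond the scatter, whereas a 1.1-fold lower number from compound 1 to compound 2 (0.02 log units; within the scatter) does not. Compound 4 `N#Cc1c(-c2ccccc2C(F)(F)F)c(C#N)c(=O)n(/N=C/c2cn(-c3ccccc3)nc2-c2ccccc2)c1N` carries the change (2-(trifluoromethyl)phenyl in place of 3,4,5-trimethoxyphenyl on an aromatic carbon). Among the compounds with values here, the two steps into compound 3 bear on this move, since each swapped a singly substituted phenyl for the trimethoxyphenyl, and no measured step speaks to the trifluoromethyl itself. Within the data shown here, because a 2.5-fold lower number from compound 1 to compound 3 (0.40 log units; beyond the scatter) and a 2.4-fold lower number from compound 2 to compound 3 (0.38 log units; beyond the scatter) were the only steps beyond the scatter and both came with the trimethoxyphenyl entering, its leaving in compound 4 is expected to undo them, by a 2.2-fold higher number from compound 3 to compound 4 (0.34 log units; beyond the scatter). Compound 4 is therefore estimated at 140 ug/mL in this assay, within a range of 70 ug/mL to 300 ug/mL.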

Compound 4, half-maximal inhibitory concentration: 56 ug/mL
For compound 4 the middle estimate is 2.5-fold (0.40 log units) above the measured one, outside the stated range (below it).
By their numbers in this assay, from the lowest: compounds 4 and 3 (each within the scatter of the next); then compounds 2 and 1 (each within the scatter of the next).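

In this assay, within the data shown here, the trimethoxyphenyl proves not to be the only group at this position that gives a low number: with 2-(trifluoromethyl)phenyl in its place there is a 1.1-fold lower number from compound 3 to compound 4 (0.06 log units; within the scatter) and, against the other two aryl groups, a 2.8-fold lower number from compound 2 to compound 4 (0.44 log units; beyond the scatter) and a 2.9-fold lower number from compound 1 to compound 4 (0.46 log units; beyond the scatter) as well. Low numbers thus occur both with and without hydrogen-bond acceptors on this phenyl. Nothing available accounts for this.

The compounds shown leave open whether the trifluoromethyl's place on the phenyl matters. Going by these compounds, how a phenyl bearing an amine or a carboxylic acid would read here also remains open.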